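The source may report more compounds than this note shows. Statements on the series, on what has been measured and on what is new or still open speak of the compounds shown alone.

Compound 1 `CC(O)(C(=O)Nc1ccc(S(=O)(=O)c2ccccc2F)cc1)C(F)(F)F` is the reference point of this account. In a functional assay (Cavia porcellus) with sulfonylurea receptors; K-ATP channels (Homo sapiens) as the target (a lower number here means a stronger inhibitor, a higher number a weaker inhibitor), compound 1 gives 1300 nM, the lowest of the two numbers reported. Its nearest neighbour among the numbers is compound 3 `CC(O)(C(=O)Nc1ccc(C(=O)c2ccccc2)cc1F)C(F)(F)F`, which in this assay gives 11000 nM; the gap between the two lies beyond the scatter of the method. Compound 2 `CO/N=C(/c1ccccc1)c1ccc(NC(=O)C(C)(O)C(F)(F)F)cc1` is reported only as a limit of this assay, namely > 30000 nM, so it does not provide a number to compare; the limit of > 30000 nM in this assay, at which 1 of the 3 values shown sits, is the relevant entry.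

Within the data shown here, no pair of measured compounds differs in a single place, so no measured step is available to guide what follows. The new compound is compound 4 `CC(O)(C(=O)Nc1ccc(S(=O)(=O)c2cncs2)cc1)C(F)(F)F`. It differs from compound 1 in one place: 1,3-thiazol-5-yl in place of 2-fluorophenyl on a sulfonyl sulfur.

Without any measured step of this kind to lean on, the step is expected to be a 2.3-fold higher number from compound 1 to compound 4 (0.36 log units; beyond the scatter), a modest weakening in this assay that may still fall within the scatter. On that basis compound 4 is expected to give about 3000 nM in this assay, with a plausible range from 800 nM to 12000 nM.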

Compound 4, half-maximal inhibitory concentration: 7700 nM
Compound 4: the middle estimate sits 2.6-fold (0.41 log units) below what was measured; low and high end bracket the measured number.
By their numbers in this assay, from the lowest: compound 1; then compounds 4 and 3 (each within the scatter of the next). At a limit, above all of these: compound 2.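

The series now has its first measured step: in this assay, the exchange on the sulfonyl sulfur gives a 5.9-fold higher number from compound 1 to compound 4 (0.77 log units; beyond the scatter), so the group held at this place does change the result. The exchange replaces a six-membered aromatic ring of carbon only, without hydrogen-bond acceptors, with a five-membered aromatic ring that has two hetero atoms and does have such acceptors, and this single change goes with a weaker inhibitor. The step moves ring size, hetero atoms and the loss of fluorine together, so it cannot assign the change to any one of them, and nothing measured here bears on the cause of the step.

The compounds shown leave open how an unsubstituted phenyl or a pyridyl ring on the sulfonyl sulfur would compare with 2-fluorophenyl and 1,3-thiazol-5-yl, a comparison that could begin to separate the fluorine, the ring size and the hetero atoms. They also leave open whether a methyl group or a short alkyl chain at this place, with no ring at all, would still give a measurable inhibitor in this assay.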